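This account rests on a few compounds, and the source may have more. Where it says the series, first, only, none or still open, it means among the compounds named here.

Compounds measured so far:

Compound 1, `N/C(CC(O)c1cccc2ccccc12)=N\N=C\c1cccc(Br)c1`: in an ADME assay on L6 cells (Rattus norvegicus) for cytotoxicity, read by resazurin assay, with a stated time of 72 h (a higher number here means a weaker inhibitor, a lower number a stronger inhibitor), compound 1 gives 3900 nM.
Compound 2, `N/C(CC(O)c1cccc2ccccc12)=N\N=C\c1ccc(F)cc1`: compound 2 gives 19000 nM.
Compound 3, `Cc1ccc(/C=N/N=C(\N)CC(O)c2cccc3ccccc23)cc1`: compound 3 gives 6800 nM.

Compound 3 sits second highest of the three numbers. Its nearest neighbour is compound 1, and the step of a 1.7-fold higher number from compound 1 to compound 3 (0.24 log units; within the scatter) stays within the scatter. Its furthest neighbour is compound 2, and the step of a 2.8-fold lower number from compound 2 to compound 3 (0.45 log units; beyond the scatter) lies beyond the scatter.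

Compound 4, `N/C(CC(O)c1cccc2ccccc12)=N\N=C\c1ccc(F)c(F)c1`, has not yet been measured. It differs from compound 3 in one place: 3,4-difluorophenyl in place of 4-methylphenyl on a carbon with a double bond to nitrogen.

Among the measured compounds shown here, two measured steps bear on this change. The step of a 2.8-fold lower number from compound 2 to compound 3 (0.45 log units; beyond the scatter) shows that methyl in place of fluoro on the aromatic carbon gave a modest lowering; the reverse direction, fluoro in place of methyl, would therefore be expected to raise the number. The step of a 4.9-fold higher number from compound 1 to compound 2 (0.69 log units; beyond the scatter) shows that the 4-fluorophenyl compound gave the highest number of the set. Both point the same way, and compound 4 carries two fluorines rather than one, so a modest rise is expected. The number for compound 4 is therefore estimated to lie near compound 2, with the step of a 2.1-fold higher number from compound 3 to compound 4 (0.31 log units; beyond the scatter) expected in this assay. The estimate for compound 4 is 14000 nM, with a range from 6000 nM to 33000 nM.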

Compound 4, half-maximal inhibitory concentration: 17000 nM
Beside the measured number, compound 4's estimate is 1.2-fold (0.08 log units) below it; low and high end bracket the measured number.
By their numbers in this assay, from the lowest: compounds 1 and 3 (each within the scatter of the next); then compounds 4 and 2 (each within the scatter of the next).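

In this assay, the step of a 1.1-fold lower number from compound 2 to compound 4 (0.05 log units; within the scatter) shows that fluoro in place of hydrogen on an aromatic carbon leaves compound 4 indistinguishable from compound 2, so the added fluorine gives no separable change in this small set. The 3,4-difluorophenyl group nevertheless gives a higher number than the 4-methylphenyl group, a 2.5-fold higher number from compound 3 to compound 4 (0.40 log units; beyond the scatter), and than the 3-bromophenyl group, a 4.4-fold higher number from compound 1 to compound 4 (0.64 log units; beyond the scatter), which places the two fluorinated compounds, compound 2 and compound 4, together above compound 1 and compound 3, with none of the four compounds going against this split. Nothing measured here gives a reason for this split.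

The compounds shown leave open where a nitrile, a methoxy group or an amine on this aromatic ring would fall in this assay, and whether a 3-fluorophenyl group alone would stand with the 4-fluorophenyl and 3,4-difluorophenyl groups. They also leave open whether the split would hold if a longer chain replaced the chain of the shared core, since all four compounds carry the same core.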